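The source may hold more compounds than are shown below. What is called first, only, known or untested is meant among the compounds shown, and "the series" means these compounds.

Measured so far:
- compound 1, `N=C(NCCCc1c[nH]cn1)NCCC(c1ccc(Cl)cc1)c1ccccn1`, gives 77.6 nM in a functional assay on ileum for antagonist activity at histamine H1 receptor (Cavia porcellus); a higher number here means weaker binding, a lower number tighter binding
- compound 2, `N=C(NCCCc1c[nH]cn1)NCCC(c1cccc(F)c1)c1ccccn1`, gives 158 nM in this assay

Compound 2 stands at the higher of the two numbers in this assay, its nearest neighbour being compound 1; the change between them was a 2.0-fold higher number from compound 1 to compound 2 (0.31 log units; beyond the scatter), so compound 2 is the weaker of the pair.

Compound 3 is `N=C(NCCCc1c[nH]cn1)NCCC(c1ccc(Cl)c(Cl)c1)c1ccccn1`. It differs from compound 2 in one place: 3,4-dichlorophenyl in place of 3-fluorophenyl on a saturated chain carbon bound to an aromatic carbon and a saturated chain carbon. This change brings back the chlorine at the position that compound 1 carries and adds a second chlorine next to it in the same ring, while the fluorine of compound 2 leaves.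

Within the data shown here, only one measured step bears on this: the move from compound 1 to compound 2, which weakened binding by a modest margin when 4-chlorophenyl gave way to 3-fluorophenyl. Reversing part of that change, and adding a second chlorine, is expected to pull the number back down toward that of compound 1, with the extra chlorine of uncertain effect. The expected step is a 2.3-fold lower number from compound 2 to compound 3 (0.35 log units; beyond the scatter). Compound 3 is therefore estimated at 70 nM in this assay, within a range from 25 nM to 200 nM.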

Compound 3, dissociation constant: 79.4 nM
The estimate for compound 3 lay 1.1-fold (0.05 log units) below the measured number; the range from low to high includes it.
By their numbers in this assay, from the lowest: compounds 1, 3 and 2 (each within the scatter of the next, the first and the last beyond it).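

Adding a chlorine to the 4-chlorophenyl ring of compound 1 gives the 3,4-dichlorophenyl ring of compound 3, and in this assay this is a 1.0-fold higher number from compound 1 to compound 3 (0.01 log units; within the scatter), so the two compounds cannot be told apart and this position on the saturated chain carbon accepts the second chlorine with no measurable difference. The step of a 2.0-fold lower number from compound 2 to compound 3 (0.30 log units; within the scatter) also stays inside the normal spread of repeat measurements, so compound 3 cannot be ranked against compound 2 either. The earlier pair showed a real gap between 4-chlorophenyl and 3-fluorophenyl, whereas 3,4-dichlorophenyl now falls in the overlap, clearly separate from neither, and only the two ends of this short series remain apart in this assay.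

On these data alone, it remains open whether plain phenyl, 3-chlorophenyl, or a ring carrying a methoxy or trifluoromethyl group would give numbers in the same range, and so whether the ring needs a halogen at all. The data shown offer no independent measurement that could explain why these rings give the numbers they do.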